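Methyl beside the ring nitrogen: estimate for compound 4

The source may hold more compounds than are shown below. What is called first, only, known or untested is meant among the compounds shown, and "the series" means these compounds.

Measured compounds:
compound 1 `N/C(=N\NC(=S)N1CCCCCC1)c1ccccn1` — 62.2%
compound 2 `N/C(=N\NC(=S)N1CCCCC1)c1ccccn1` — 53.1%
compound 3 `Cc1ccnc(/C(N)=N/NC(=S)N2CCCCCC2)c1` — 60.3%

In a functional assay on MCF7 cells (Homo sapiens) for cytotoxicity, read by MTT assay, with a stated time of 72 h, tested at 10 uM (on this read-out lower numbers stand for less inhibition of growth and higher numbers for more inhibition of growth at the one concentration tested), compound 1 gives 62.2%, the highest of the three numbers, although compound 3 with 60.3% and compound 2 with 53.1% both sit within the scatter of it. Compound 4 `Cc1cccc(/C(N)=N/NC(=S)N2CCCCCC2)n1` differs from compound 1 by methyl in place of hydrogen on an aromatic carbon. Among the measured compounds shown here, the one measured step that bears on a ring methyl is a number 1.9 percentage points lower from compound 1 to compound 3 (within the scatter), and it lay within the scatter. For the measured compounds named here, no measured step puts the methyl next to the ring nitrogen, so that site is untested. The expected step of a number 4.2 percentage points lower from compound 1 to compound 4 (within the scatter) is therefore none beyond the scatter. Compound 4 is estimated at 58%, with a range from 44% to 70%.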

Compound 4, percent growth inhibition at one concentration: 21.5%
For compound 4 the middle estimate is 36.5 percentage points above the measured one; measured number outside the range, below it.
By their numbers in this assay, from the lowest: compound 4; then compounds 2, 3 and 1 (each within the scatter of the next).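

In this assay, methyl in place of hydrogen next to the ring nitrogen comes with a number 40.7 percentage points lower from compound 1 to compound 4 (beyond the scatter), whereas the same exchange in compound 3 comes with a number 1.9 percentage points lower from compound 1 to compound 3 (within the scatter). The effect of this change therefore depends on where the methyl stands on the ring, and of the two sites shown, only the one next to the ring nitrogen gives a step beyond the scatter. Going by these compounds, whether a fluorine atom or an amine at this position would keep the number near that of compound 1 stays open, as does the size of the methyl step on the core of compound 2. No available evidence explains the drop.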